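The source may hold more compounds than are shown below. What is called first, only, known or untested is meant among the compounds shown, and "the series" means these compounds.

Measured so far:
- Compound 1 `O=C(O)c1ccc(C(=O)/C(=C\c2ccc(Br)c([N+](=O)[O-])c2)SCc2ccccc2Cl)cc1`: in a functional assay on DU-145 cells (Homo sapiens) for inhibition, read by trypan blue exclusion, with a stated time of 96 h (a lower number here means a stronger inhibitor of growth, a higher number a weaker inhibitor of growth), compound 1 gives 1000 nM.
- Compound 2 `COc1ccccc1/C=C(/SCc1ccc(C)cc1)C(=O)c1ccc(Cl)cc1`: in this assay compound 2 gives 10000 nM.

Compound 1 has the lowest number of the two; the gap to compound 2 lies beyond the scatter. Compound 3 `O=C(O)c1ccc(C(=O)/C(=C\c2ccc(Br)c([N+](=O)[O-])c2)SCc2ccc(Br)cc2)cc1` differs from compound 1 in one place: 4-bromophenyl in place of 2-chlorophenyl on a saturated chain carbon bound to a sulfur. Going by the values given here, no step between measured compounds tracks this change, so in this assay the expected step is none beyond the scatter, in either direction. Compound 3 is therefore expected at 1000 nM, with a range from 400 nM to 2500 nM. The step this expectation means is no change at the digits printed from compound 1 to compound 3 (within the scatter).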

Compound 3, concentration for 50% growth inhibition: 1000 nM
For compound 3 middle estimate and measured number coincide at the digits printed; the range from low to high includes it.
By their numbers in this assay, from the lowest: compounds 1 and 3 (each within the scatter of the next); then compound 2.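

In this assay, going by these compounds alone, replacing 2-chlorophenyl with 4-bromophenyl on a saturated chain carbon bound to a sulfur gives no change at the digits printed from compound 1 to compound 3 (within the scatter) and provides the first one-place comparison at this position. Nothing on hand offers a reason for this result. Halogen identity and ring position change together here. 2-Bromophenyl and 4-chlorophenyl remain the missing pair for separating them. Also open, on these data alone, is whether the same position would accept an aminophenyl ring or an unsubstituted hexyl chain in place of these halogenated rings.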